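Ethyl Ester Versus Free Acid on Two Related Cores

The source may hold more compounds than are shown below. What is called first, only, known or untested is meant among the compounds shown, and "the series" means these compounds.

The study turns on a single small change, made on two different cores, and read in a functional assay on JeKo-1 cells (Homo sapiens) for inhibition, read by luminescence and CellTiter-Glo, with a stated time of 72 h; on this read-out higher numbers stand for weaker inhibition and lower numbers for stronger inhibition. Compound 1 `C/C=C/C(=O)Nc1ccc(Cn2nc(-c3ccc(Oc4ccccc4)cc3)cc2C(=O)O)cc1` carries a free carboxylic acid. In this assay compound 1 gives > 60000 nM, which is a limit of the assay and not a number. Compound 2 `C/C=C/C(=O)Nc1ccc(Cn2nc(-c3ccc(Oc4ccccc4)cc3)cc2C(=O)OCC)cc1` differs from compound 1 by ethyl in place of hydrogen on an oxygen next to a carbonyl group. In this assay compound 2 gives 52500 nM. The step recorded is an at least 1.1-fold lower number from compound 1 to compound 2 (0.05 log units; that floor lies within the scatter), so the two values cannot be told apart with confidence; what can be said is that compound 2 returned a number where compound 1 returned only (the limit of > 60000 nM in this assay, at which 2 of the 3 values shown sit).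

Compound 3 `C=CC(=O)N1CCCC(n2nc(-c3ccc(Oc4ccccc4)cc3)cc2C(=O)O)C1` is the free acid on a second core. The difference between the core of compound 1 and the core of compound 3 is not broken down here. In this assay compound 3 gives > 60000 nM, which is again a limit of the assay and not a number.

Compound 4 `C=CC(=O)N1CCCC(n2nc(-c3ccc(Oc4ccccc4)cc3)cc2C(=O)OCC)C1` is not yet measured and differs from compound 3 by ethyl in place of hydrogen on an oxygen next to a carbonyl group, the same change that separates compound 1 from compound 2. Since the measured pair moved by only an at least 1.1-fold lower number from compound 1 to compound 2 (0.05 log units; that floor lies within the scatter), the step from compound 3 to compound 4 is expected to be about an at least 1.2-fold lower number from compound 3 to compound 4 (0.09 log units; that floor lies within the scatter). On that basis compound 4 is estimated to give roughly 48000 nM in this assay, expected to lie between 18000 nM and 120000 nM, with a real chance that the assay again reports only a limit.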

Compound 4, half-maximal inhibitory concentration: 21200 nM
Compound 4: middle estimate off by 2.3-fold (0.35 log units), on the high side, within the range that was stated.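

In this assay, ethyl in place of hydrogen on an oxygen next to a carbonyl group gives an at least 2.8-fold lower number from compound 3 to compound 4 (0.45 log units; beyond the scatter), so on the core of compound 3 the change has an effect that stands clear of the scatter. This is the only place in the series shown where that can be said, and it does not show that the change carries from one core to the other with a fixed size, since the two steps cannot be told apart: the same change on two cores in this assay, an at least 1.1-fold lower number (0.05 log units; that floor lies within the scatter) from compound 1 to compound 2 and an at least 2.8-fold lower number (0.45 log units; beyond the scatter) from compound 3 to compound 4; the limit leaves it open whether they differ Each step is known only as a floor, and the free acids, compound 1 and compound 3, give a limit of the assay and not a number: the limit of > 60000 nM in this assay, at which 2 of the 4 values shown sit.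

The compounds shown leave open whether a methyl ester, a longer chain on the same oxygen or an amide in place of the ester would give a step of similar size on either core. They also leave open whether the ethyl change would behave in the same way on a third core, since the two pairs here rest on just two cores.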